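Nitro for hydroxy at the weak end of the series

A few compounds are considered here, and "the series" means these few. Any claim that something is new, unique, unknown or untested is made for them only; others in the source may bear on it.

Measured in a functional assay on K562 cells (Homo sapiens) for cytotoxicity, read by MTT assay, with a stated time of 5 days; a lower number here means a stronger inhibitor, a higher number a weaker inhibitor:
- Compound 1 `COc1ccc(-c2cn(-c3cc(OC)c(OC)c(OC)c3)nn2)cc1N`: 1300 nM
- Compound 2 `COc1ccc(-c2cn(Cc3cc(OC)c(OC)c(OC)c3)nn2)cc1O`: > 10000 nM

Compound 2 gives no number in this assay, and its > 10000 nM is a limit of the assay. Compound 3 `COc1ccc(-c2cn(Cc3cc(OC)c(OC)c(OC)c3)nn2)cc1[N+](=O)[O-]` keeps the rest of compound 2 and differs as follows: nitro in place of hydroxy on an aromatic carbon. This places nitro in place of hydroxy on an aromatic carbon, ortho to a methoxy group. For the measured compounds named here, no measured step isolates this change, so the expectation rests on little. In this assay, no step beyond the scatter is expected, and the result should stay in the weak range where compound 2 sits at > 10000 nM. The expected size of the change is a step that the limit leaves unreadable from compound 2 to compound 3. A report of only a limit is also expected to be likely. For compound 3 the estimate is 12000 nM, with an expected range of 3000 nM to 40000 nM.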

Compound 3, half-maximal inhibitory concentration: > 10000 nM
Compound 3 ended at the assay's limit (the forecaster's own chance of this, stated with the estimate: 65%); the middle value does not contradict the limit.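

In this assay compound 2 gives > 10000 nM, a limit and not a number. For the compounds shown here, compound 3 gives > 10000 nM, also a limit, so no step between compound 2 and compound 3 can be read. On these data alone, what nitro in place of hydroxy does to potency stays open.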